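A few compounds are considered here, and "the series" means these few. Any claim that something is new, unique, unknown or untested is made for them only; others in the source may bear on it.

Compound 1 `C[C@H](Nc1nc(O)c2cc(Cl)ccc2n1)C1CCCCC1` and compound 2 `C[C@H](Nc1nc(O)c2cc(Cl)ccc2n1)c1ccccc1` share one core and differ in one place: phenyl in place of cyclohexyl on a saturated chain carbon bound to a nitrogen on an aromatic ring and a saturated chain carbon. In a functional assay on the whole organism (uterus) with Rattus norvegicus as the target, tested at 10 uM (on this read-out higher numbers stand for a weaker effect at the one concentration tested and lower numbers for a stronger effect), compound 1 gives 102%, while compound 2 gives 92.4%, so the change made a number 9.6 percentage points lower from compound 1 to compound 2 (within the scatter). Compound 3 `Oc1nc(NCC2CCCCC2)nc2ccc(I)cc12` has a different core; how its core differs from that of compound 1 is not broken down here. In this assay compound 3 gives 96.8%. Compound 4 `Oc1nc(NCc2ccccc2)nc2ccc(I)cc12` is to be measured in this assay and differs from compound 3 by phenyl in place of cyclohexyl on a saturated chain carbon bound to a nitrogen on an aromatic ring. This is the same kind of change as that from compound 1 to compound 2, though the place differs: in compound 1 the saturated chain carbon is also bound to a further saturated chain carbon, in compound 3 it is not. Because the earlier change gave a number 9.6 percentage points lower from compound 1 to compound 2 (within the scatter), a step of a number 6.8 percentage points lower from compound 3 to compound 4 (within the scatter) is expected for compound 4. Compound 4 is therefore estimated to give 90% in this assay, with a range from 75% to 105%.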

Compound 4, a percentage reported as activity, at one concentration (the size of the read-out at that concentration, not a potency): 106%
The estimate for compound 4 lay 16 percentage points below the measured number; the measured number lies above the stated range.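

Phenyl in place of cyclohexyl gives a number 9.2 percentage points higher from compound 3 to compound 4 (within the scatter) in this assay. Set beside the earlier step, this shows that the change does not carry over as a fixed step from one core to the other: the same change on two cores in this assay, a number 9.6 percentage points lower (within the scatter) from compound 1 to compound 2 and a number 9.2 percentage points higher (within the scatter) from compound 3 to compound 4, 18.8 percentage points apart, beyond the scatter of two such steps Each step alone lies within the scatter, however, and two pairs cannot show which difference between the cores, or whether the further saturated chain carbon present in compound 1, lies behind the gap.

The compounds shown leave open how the same change behaves on other cores. They also leave open whether a longer chain between the nitrogen and the ring, or an amine on the ring, would move the read-out beyond the scatter.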